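Moving a Trifluoromethyl Group Around a Benzyl Ether

A few compounds are considered here, and "the series" means these few. Any claim that something is new, unique, unknown or untested is made for them only; others in the source may bear on it.

Three compounds share one core and were measured in an assay on isolated protein (kidney, strain Wistar) for displacement of a labelled ligand from Translocator protein (Rattus norvegicus), read by scintillation counting, with a stated time of 90 min; on this read-out higher numbers stand for weaker inhibition and lower numbers for stronger inhibition:

Compound 1, `CCN(CC)C(=O)Cc1c(-c2ccc(OC3CCCC3)cc2)nn2c(C)cc(C)nc12`: 1.5 nM
Compound 2, `CCN(CC)C(=O)Cc1c(-c2ccc(OCc3ccccc3)cc2)nn2c(C)cc(C)nc12`: 0.99 nM
Compound 3, `CCN(CC)C(=O)Cc1c(-c2ccc(OCc3ccccc3C(F)(F)F)cc2)nn2c(C)cc(C)nc12`: 1.4 nM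

All three numbers sit close together. The step of a 1.5-fold lower number from compound 1 to compound 2 (0.18 log units; within the scatter) and the step of a 1.1-fold lower number from compound 1 to compound 3 (0.03 log units; within the scatter) both lie within the scatter, and so does the step of a 1.4-fold higher number from compound 2 to compound 3 (0.15 log units; within the scatter). Compound 3 therefore cannot be set apart from either neighbour on the numbers shown; its value is indistinguishable from that of compound 1 and that of compound 2.

Compound 4, `CCN(CC)C(=O)Cc1c(-c2ccc(OCc3cccc(C(F)(F)F)c3)cc2)nn2c(C)cc(C)nc12`, has not been measured. It differs from compound 3 only in where the trifluoromethyl group sits: 3-(trifluoromethyl)phenyl in place of 2-(trifluoromethyl)phenyl on a saturated chain carbon bound to an oxygen on an aromatic ring. Among the measured compounds shown here, the one measured step that touches this group, a 1.4-fold higher number from compound 2 to compound 3 (0.15 log units; within the scatter), shows that adding the trifluoromethyl group at all made no difference beyond the scatter, and the exchange of cyclopentyl for either benzyl group in a 1.5-fold lower number from compound 1 to compound 2 (0.18 log units; within the scatter) and a 1.1-fold lower number from compound 1 to compound 3 (0.03 log units; within the scatter) likewise changed nothing that can be resolved. Nothing in these data points to a shift from relocating the group, so compound 4 is expected to give a step of a 1.1-fold lower number from compound 3 to compound 4 (0.03 log units; within the scatter) that stays within the scatter. The estimate for compound 4 in this assay is 1.3 nM, with a range from 0.5 nM to 4 nM.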

Compound 4, inhibition constant: 0.67 nM
Estimate against measurement, compound 4: 1.9-fold (0.29 log units) above, and the stated range covers the measured number.
By their numbers in this assay, from the lowest: compounds 4, 2, 3 and 1 (each within the scatter of the next, the first and the last beyond it).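

In this assay, among the compounds shown here, where the trifluoromethyl group sits on the benzyl ring proves to matter more than whether the group is present: replacing 2-(trifluoromethyl)phenyl with 3-(trifluoromethyl)phenyl gives a 2.1-fold lower number from compound 3 to compound 4 (0.32 log units; beyond the scatter) and is a modest change, whereas no step among the earlier compounds cleared the scatter. The new placement does not separate the trifluoromethyl compound from the plain benzyl ether, as a 1.5-fold lower number from compound 2 to compound 4 (0.17 log units; within the scatter) shows, but it does produce the first resolved difference from the cyclopentyl ether, with a 2.2-fold lower number from compound 1 to compound 4 (0.35 log units; beyond the scatter) as another modest step. No available evidence accounts for this difference between the two placements.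

The compounds shown leave open whether the difference belongs to trifluoromethyl itself or would also appear with a chlorine, a methoxy or a nitrile on the same ring. They also do not show whether it would survive a longer chain between the oxygen and the aromatic ring, as in a phenethyl ether, or a change to the diethyl amide of the shared core.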